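Swapping chloro for methoxy on a weak antiproliferative scaffold

The source may hold more compounds than are shown below. What is called first, only, known or untested is meant among the compounds shown, and "the series" means these compounds.

Compound 1 `Cc1ccc(-c2cc(NC(=O)c3cccnc3Cl)n[nH]2)cc1` carries a chloro group on its pyridine-type ring; in a functional assay on WM1361 cells (Homo sapiens) for antiproliferative activity, read by MTT assay, with a stated time of 48 h (a higher number here means a weaker inhibitor, a lower number a stronger inhibitor), compound 1 gives 15800 nM. Compound 2 `COc1ncccc1C(=O)Nc1cc(-c2ccc(C)cc2)[nH]n1` differs from it only by methoxy in place of chloro on an aromatic carbon, and in this assay compound 2 gives 25800 nM, so a 1.6-fold higher number from compound 1 to compound 2 (0.21 log units; within the scatter). Compound 3 `O=C(Nc1cc(-c2ccc(Br)cc2)[nH]n1)c1ccc(Cl)nc1` keeps the chloro group but its core differs from that of compound 1 in a way that is not broken down here; in this assay compound 3 gives 19300 nM. Compound 4 `COc1ccc(C(=O)Nc2cc(-c3ccc(Br)cc3)[nH]n2)cn1` is not yet measured and differs from compound 3 by methoxy in place of chloro on an aromatic carbon. This is the same kind of change as from compound 1 to compound 2, though there the methoxy sits ortho to a large group, here para to it. Because a 1.6-fold higher number from compound 1 to compound 2 (0.21 log units; within the scatter) stayed within the scatter, the expected step is a 1.6-fold higher number from compound 3 to compound 4 (0.19 log units; within the scatter). Compound 4 is therefore estimated at 30000 nM, between 15000 nM and 60000 nM.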

Compound 4, half-maximal inhibitory concentration: 28500 nM
For compound 4 the middle estimate is 1.1-fold (0.02 log units) above the measured one; the range from low to high includes it.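

Replacing chloro with methoxy in this assay gives a 1.5-fold higher number from compound 3 to compound 4 (0.17 log units; within the scatter). Set beside the earlier step, the change carries over from one core to the other with much the same size: the same change on two cores in this assay, a 1.6-fold higher number (0.21 log units; within the scatter) from compound 1 to compound 2 and a 1.5-fold higher number (0.17 log units; within the scatter) from compound 3 to compound 4, 1.1-fold (0.04 log units) apart, within the scatter of two such steps. This does not show a real difference between methoxy and chloro on either core, as both steps lie within the scatter, and two cores do not make a rule for the whole series.

The compounds shown leave open whether a different group at this place, such as an amine or a longer chain like ethoxy, would give a step beyond the scatter. Also open, on these data alone, is how the swap behaves on other cores.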